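Chloro substitution on the core of compound 1

The source may hold more compounds than are shown below. What is called first, only, known or untested is meant among the compounds shown, and "the series" means these compounds.

Measured so far:
Compound 1 `CC(C)NC1=NS(=O)(=O)c2cccnc2N1`: in a functional assay (ileum) for inhibition, with Cavia porcellus as the target (a lower number here means that less compound is needed, a higher number that more compound is needed for the effect), compound 1 gives > 300 uM, which is a limit of the assay.
Compound 2 `CC(C)C(C)NC1=NS(=O)(=O)c2cccnc2N1`: in this assay compound 2 gives > 300 uM, also a limit.
Compound 3 `CC(NC1=NS(=O)(=O)c2cccnc2N1)C(C)(C)C`: in this assay compound 3 gives > 300 uM, again a limit.

Compound 1 stands at the limit, and so do the other two; none of the three has a number. The steps among them, a step that the two limits leave unreadable from compound 1 to compound 2, a step that the two limits leave unreadable from compound 1 to compound 3 and a step that the two limits leave unreadable from compound 2 to compound 3, are all unreadable because of the limit of > 300 uM in this assay, at which 3 of the 3 values shown sit. They concern the chain on the amine nitrogen and say nothing about the aromatic part of the core.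

Compound 4 `CC(C)NC1=NS(=O)(=O)c2cc(Cl)cnc2N1` differs from compound 1 by chloro in place of hydrogen on an aromatic carbon. Going by the values given here, no measured step touches this position, so no expected size in this assay can be taken from the measured pairs; the only anchor is that compound 1 sits at the limit. Compound 4 is therefore expected to stay near the limit as well, with a wide range on either side. For compound 4 the estimate in this assay is 400 uM, between 100 uM and 2000 uM. This corresponds to an expected step that the limit leaves unreadable from compound 1 to compound 4, most likely reported again only as a limit.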

Compound 4, concentration for half-maximal effect: > 300 uM
Compound 4: only a limit was reported; the forecaster's own chance of this, stated with the estimate: 70%; the middle value lies beyond the limit too.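

Going by these compounds alone, no step from compound 1 to compound 4 can be read, because both compounds stand only at a limit: the limit of > 300 uM in this assay, at which 4 of the 4 values shown sit. From the compounds shown here alone, whether chloro in place of hydrogen on this aromatic carbon shifts the concentration needed in this assay, in either direction, stays open, as does whether any change to the shared core gives a readable value.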